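A few compounds are considered here, and "the series" means these few. Any claim that something is new, unique, unknown or untested is made for them only; others in the source may bear on it.

Measured so far:
- compound 1, `COc1cc(-c2cc(/C=C/C(=O)c3ccc(N)cc3)[nH]n2)cc(OC)c1OC`, in a functional assay on MDA-MB-231 cells (Homo sapiens) for cytotoxicity, read by sulforhodamine B assay, with a stated time of 48 h, tested at 0.01 uM; a higher number here means a weaker effect of the compound at the concentration tested, a lower number a stronger effect: compound 1 gives 109%
- compound 2, `COc1ccc(-c2cc(/C=C/C(=O)c3ccc(N)cc3)[nH]n2)cc1OC`: compound 2 gives 113%
- compound 3, `COc1cc(C(=O)/C=C/c2cc(-c3cc(OC)c(OC)c(OC)c3)n[nH]2)cc(OC)c1OC`: compound 3 gives 110%

All three numbers lie within the scatter of one another, so none of the three can be called stronger or weaker than the others. Compound 4, `COc1ccc(-c2cc(/C=C/C(=O)c3cc(OC)c(OC)c(OC)c3)[nH]n2)cc1OC`, has not yet been tested.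

The change from compound 3 to compound 4 is hydrogen in place of methoxy on an aromatic carbon. The same change, (hydrogen in place of methoxy on an aromatic carbon), was already made between two measured compounds: it gave a number 4 percentage points higher from compound 1 to compound 2 (within the scatter). The two pairs sit on different cores, and the difference between the core of compound 1 and the core of compound 3 is not broken down here.

Because a number 4 percentage points higher from compound 1 to compound 2 (within the scatter) stayed within the scatter, the step expected from compound 3 to compound 4 in this assay is estimated as a number 2 percentage points higher from compound 3 to compound 4 (within the scatter), a movement of the same small size as the earlier one. On that basis the expected value for compound 4 is 112%, with a likely range from 100% to 124%.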

Compound 4, a percentage reported as activity, at one concentration (the size of the read-out at that concentration, not a potency): 98%
The estimate for compound 4 lay 14 percentage points above the measured number; measured number outside the range, below it.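

In this assay, hydrogen in place of one methoxy group gives a number 12 percentage points lower from compound 3 to compound 4 (beyond the scatter), a modest strengthening of the effect at the single concentration tested. The same change does not carry over with the same result from the core of compound 1 to the core of compound 3: the same change on two cores in this assay, a number 4 percentage points higher (within the scatter) from compound 1 to compound 2 and a number 12 percentage points lower (beyond the scatter) from compound 3 to compound 4, 16 percentage points apart, beyond the scatter of two such steps. This shows that, in these two pairs, the outcome of the change differs with the core, but two pairs give no general rule for other cores, do not identify which part of the cores matters, and, as single-concentration read-outs, do not measure potency.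

The compounds shown leave open whether a hydroxy group or a longer chain such as ethoxy in place of the same methoxy group would move the number as hydrogen does. They also leave open how the change would behave on a core carrying a carboxylic acid or a chlorine atom instead of the amine of compound 1.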